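Shortening the Alkyl Chain on a Shared Purine-Like Core

The compounds below may be only part of what the source reports. "The series", "measured", "known", "first", "only" and "open" are said of these compounds alone.

Compound 1, `CCCCCNc1nc(N)c2nc(O)n(Cc3ccccc3)c2n1`, gives 0.3 mg/kg in a functional assay on the whole organism for activation, with Mus musculus as the target; on this read-out higher numbers stand for an effect only at larger amounts of compound and lower numbers for an effect already at smaller amounts.
Compound 2, `CCCCNc1nc(N)c2nc(O)n(Cc3ccccc3)c2n1`, gives 0.1 mg/kg in this assay.

Among the two measured compounds, compound 2 has the lowest number, so it produces its effect at the smaller amount of substance. For the measured compounds named here, the only step between them, a 3.0-fold lower number from compound 1 to compound 2 (0.48 log units; beyond the scatter), involves hydrogen in place of methyl on a saturated chain carbon, four bonds along the chain from a nitrogen on an aromatic ring; the chain became one carbon shorter and the dose needed fell.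

Compound 3, `CCCNc1nc(N)c2nc(O)n(Cc3ccccc3)c2n1`, carries the same kind of change one bond closer in: hydrogen in place of methyl on a saturated chain carbon, three bonds along the chain from a nitrogen on an aromatic ring. Going by the values given here, only the step from compound 1 to compound 2 bears on it, and that step was modest. Whether shortening the chain again continues that direction or stops cannot be read from a single step, so the expectation is a small further lowering at most, with none beyond the scatter also plausible. For compound 3 the expected step is a 1.3-fold lower number from compound 2 to compound 3 (0.10 log units; within the scatter). Compound 3 is therefore estimated at 0.08 mg/kg, with a range from 0.025 mg/kg to 0.25 mg/kg.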

Compound 3, minimum effective dose: 1 mg/kg
Estimate against measurement, compound 3: 13-fold (1.10 log units) below; the measured number lies above the stated range.
By their numbers in this assay, from the lowest: compound 2; then compound 1; then compound 3.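

Shortening the chain once more does not continue the earlier direction: the butyl to propyl change gives a 10-fold higher number from compound 2 to compound 3 (1.00 log units; beyond the scatter) in this assay, whereas the pentyl to butyl change gave a 3.0-fold lower number from compound 1 to compound 2 (0.48 log units; beyond the scatter). Among these three compounds, the lowest number therefore belongs to the butyl chain of compound 2, with both the longer and the shorter chain needing a larger dose, so swapping methyl for hydrogen at one place along the chain says little about the same swap one bond closer to the ring nitrogen. The propyl chain also falls behind the pentyl chain, with a 3.3-fold higher number from compound 1 to compound 3 (0.52 log units; beyond the scatter), and nothing available here explains this reversal.

For the compounds shown here, with only three chain lengths, the shape of this dependence rests on very few points, and a single measurement at each length carries much of the weight. On these data alone, it remains open whether an ethyl or a hexyl chain would follow the same rise on either side of butyl, and whether a branched isobutyl chain or a butyl chain carrying an amine would keep the low dose of compound 2.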